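Adding bromo to the core of compound 2

A few compounds are considered here, and "the series" means these few. Any claim that something is new, unique, unknown or untested is made for them only; others in the source may bear on it.

Going by the values given here, in a functional assay on SK-OV-3 cells (Homo sapiens) (a lower number here means a stronger inhibitor of growth, a higher number a weaker inhibitor of growth), compound 2 `O=S(=O)(/C=C/c1ccc(C(F)(F)F)cc1F)Cc1ccc(Nc2ncnc3ccccc23)cc1` gives 39000 nM, the highest of the three numbers so far. By comparison, compound 3 `O=S(=O)(/C=C/c1ccc(O)cc1)Cc1ccc(Nc2ncnc3ccccc23)cc1` gives 14000 nM and compound 1 `O=S(=O)(/C=C/c1ccc(Cl)cc1Cl)Cc1ccc(Nc2ncnc3ccccc23)cc1` gives 2000 nM. Compound 4 `O=S(=O)(/C=C/c1ccc(C(F)(F)F)cc1F)Cc1ccc(Nc2ncnc3ccc(Br)cc23)cc1` keeps the 2-fluoro-4-(trifluoromethyl)phenyl group of compound 2 but changes the shared core: bromo in place of hydrogen on an aromatic carbon. Among the compounds with values here, no measured step touches this place. The measured steps only swap the phenyl group, for example a 20-fold higher number from compound 1 to compound 2 (1.29 log units; beyond the scatter) and a 2.8-fold lower number from compound 2 to compound 3 (0.44 log units; beyond the scatter), so they show how far numbers can move in this series, not what bromo does. Within the data shown here, compound 2 gives 39000 nM and no other measured compound exceeds it, so a fall seems likelier than a rise. The estimated change is small: a 2.2-fold lower number from compound 2 to compound 4 (0.34 log units; beyond the scatter). Compound 4 is expected near 18000 nM, within an estimated range of 5000 nM to 60000 nM.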

Compound 4, concentration for 50% growth inhibition: 5000 nM
For compound 4 the middle estimate is 3.6-fold (0.56 log units) above the measured one, and the stated range covers the measured number.
By their numbers in this assay, from the lowest: compound 1; then compound 4; then compound 3; then compound 2.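

In this assay the shared core turns out to matter as well: bromo in place of hydrogen on an aromatic carbon gives a 7.8-fold lower number from compound 2 to compound 4 (0.89 log units; beyond the scatter) with the phenyl group unchanged. Going by these compounds alone, the earlier compounds varied only the phenyl group, so this is the first sign that this ring position can shift the number. Nothing at hand explains the step. From the compounds shown here alone, whether bromo has the same effect alongside the 2,4-dichlorophenyl group of compound 1 remains open, as does whether an amine or a methoxy group at this carbon would act like bromo.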